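Swapping a Halogen on the Aromatic Ring of Compound 3

This account rests on a few compounds, and the source may have more. Where it says the series, first, only, none or still open, it means among the compounds named here.

Of the compounds shown here, three have been tested in a functional assay on the whole organism (strain Swiss) with Mus musculus as the target, in the maximal electroshock model, with a stated time of 0.5 h, at a dose of 300 mg/kg by the intraperitoneal route; on this read-out higher numbers stand for a stronger effect at the one dose given and lower numbers for a weaker effect. Compound 1 `CCC(C(=O)N1CCN(c2cccc(Cl)c2)CC1)N1C(=O)CCC1=O` gives 50%. Compound 2 `CC(C(=O)N1CCN(c2ccccc2C(F)(F)F)CC1)N1C(=O)CCC1=O` gives 100%. Compound 3 `CC(C(=O)N1CCN(c2cccc(Cl)c2)CC1)N1C(=O)CCC1=O` gives 100%, level with compound 2 and together the highest of the three. Among the compounds with values here, the only single-point step measured is a number 50 percentage points higher from compound 1 to compound 3 (beyond the scatter). Compound 4 `CC(C(=O)N1CCN(c2cccc(F)c2)CC1)N1C(=O)CCC1=O` is compound 3 with fluoro in place of chloro on an aromatic carbon. Within the data shown here, no measured step touches this change, and compounds 2 and 3 differ in two places, so their values show only that both reach the top of the scale. The expectation is therefore a step of a number 5 percentage points lower from compound 3 to compound 4 (within the scatter), nothing beyond the scatter. Compound 4 is estimated at 95%, between 70% and 100%.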

Compound 4, a percentage reported as activity, at one dose (the size of the read-out at that dose, not a potency): 50%
Beside the measured number, compound 4's estimate is 45 percentage points above it; the whole stated range lies above it.
By their numbers in this assay, from the lowest: compounds 1 and 4 (each within the scatter of the next); then compounds 2 and 3 (each within the scatter of the next).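

In this assay, fluoro in place of chloro on this aromatic carbon gives a number 50 percentage points lower from compound 3 to compound 4 (beyond the scatter) and so shows that this swap of one halogen for another is far from silent. The earlier compounds shown here could not show this, since none of their measured steps touched this aromatic ring, and it now appears that the read-out depends on which halogen sits at this position. Nothing measured here explains the drop. Going by these compounds, whether bromo, methyl or methoxy on the same carbon would match compound 3 or fall to the level of compound 4 remains open.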